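A Sulfur Substituent Swap on Compound 3

The source may hold more compounds than are shown below. What is called first, only, known or untested is meant among the compounds shown, and "the series" means these compounds.

Measured in a functional assay on DU-145 cells (Homo sapiens) for inhibition, read by trypan blue exclusion, with a stated time of 96 h; a higher number here means a weaker inhibitor of growth, a lower number a stronger inhibitor of growth:
- compound 1 `Cc1cc(C)cc(/C=C(/SCc2ccc(F)cc2)C(=O)c2ccc(Br)cc2)c1`: 10000 nM
- compound 2 `COc1ccc(S(=O)(=O)/C(=C/c2ccc(C)s2)C(=O)c2ccc(Cl)cc2)cc1`: 25000 nM
- compound 3 `O=C(/C(=C\c1ccc(F)cc1C(F)(F)F)SCc1ccc(F)cc1)c1ccc(Br)cc1`: 10000 nM

Compound 3 stands level with compound 1, and the two share the lowest number in this small set. Compound 2 has a higher number, and that gap lies beyond the usual scatter of repeated measurements.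

The next compound to be tested is compound 4 `Cc1ccc(S/C(=C/c2ccc(F)cc2C(F)(F)F)C(=O)c2ccc(Br)cc2)cc1`. It differs from compound 3 by 4-methylphenyl in place of 4-fluorobenzyl on a sulfur, with 4-methylphenyl in place of 4-fluorobenzyl on a sulfur.

For the measured compounds named here, no two measured compounds differ in only one place, so the data give no direct guide to this swap. All that remains is the narrow spread of values, from compound 3 at 10000 nM to compound 2 at 25000 nM. On that basis, no step beyond the scatter is expected in this assay, in either direction. The estimated change is no change at the digits printed from compound 3 to compound 4 (within the scatter). For compound 4, the expected value is 10000 nM, with an estimated range of 3000 nM to 30000 nM.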

Compound 4, concentration for 50% growth inhibition: 25000 nM
Estimate against measurement, compound 4: 2.5-fold (0.40 log units) below; low and high end bracket the measured number.
By their numbers in this assay, from the lowest: compounds 1 and 3 (each within the scatter of the next); then compounds 2 and 4 (each within the scatter of the next).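

For the compounds shown here, this is the first pair in the set that differs in only one place, so the group on the sulfur can now be judged directly. In this assay, 4-methylphenyl in place of 4-fluorobenzyl gives a 2.5-fold higher number from compound 3 to compound 4 (0.40 log units; beyond the scatter) and so a modestly weaker inhibitor of growth, which shows that this position is not indifferent to the group it carries. Nothing available explains this shift.

The compounds shown leave open which feature of the swap goes with the step, and a plain benzyl or a 4-fluorophenyl group on the same sulfur would help to separate the two groups' features. Going by these compounds, it also remains open whether the same swap would give a similar step on compound 1, which carries 4-fluorobenzyl on its sulfur too.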